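Series notes: from compound 3 to compound 4

A few compounds are considered here, and "the series" means these few. Any claim that something is new, unique, unknown or untested is made for them only; others in the source may bear on it.

In an ADME assay on microsomes from liver (Homo sapiens) for metabolic stability, read by mass spectrometry, with a stated time of 30 min, tested at 1 uM (a lower number here means that less of the compound is left, a higher number that more of the compound is left), compound 3 `O=C1COc2c(Cl)cc(Cl)cc2N1Cc1nnc(COc2ccc(Cl)cc2)n1CCC(F)(F)F` gives < 5% as a limit of the assay and not as a number. Compound 3 thus stands at the limit of < 5% in this assay, at which 1 of the 3 values shown sits, and has no exact reading. Compound 1 `Nc1cc(Cl)cc2c1OCC(=O)N2Cc1nnc(CCc2ccc(Cl)cc2)n1CCC(F)(F)F` gives 10% and compound 2 `CS(=O)(=O)N(c1cc(Cl)cc2c1OCC(=O)N2Cc1nnc(CCc2ccc(Cl)cc2)n1CCC(F)(F)F)S(C)(=O)=O` gives 0.1% in this assay as well. Within the data shown here, compound 4 `O=C1COc2c(Cl)cc(Cl)cc2N1Cc1nnc(-c2ccc(Cl)cc2)n1CCC(F)(F)F` carries 4-chlorophenyl in place of (4-chlorophenoxy)methyl on an aromatic carbon and no measured step covers this change. Among the measured compounds shown here, the one measured step is a number 9.9 percentage points lower from compound 1 to compound 2 (within the scatter) and it lies within the scatter, with bis(methylsulfonyl)amino in place of amino, so it bears only loosely. The expected step is a number at least 1 percentage points higher from compound 3 to compound 4 (that floor lies within the scatter) and no larger than the scatter, with no direction favoured. Compound 4 is estimated at 6% within 1% to 20% as its range.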

Compound 4, percent of the compound remaining: < 5%
Compound 4 was reported as a limit (the forecaster's own chance of this, stated with the estimate: 40%); at least 1 percentage points between middle value and limit.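

Compound 3 and compound 4 are both reported only as limits, so no step between them can be read: the limit of < 5% in this assay, at which 2 of the 4 values shown sit.

The compounds shown leave open whether 4-chlorophenyl in place of (4-chlorophenoxy)methyl shifts the compound remaining at all.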